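Arylsulfonyl piperidinylpiperidines: cytotoxicity notes on the series

The source may report more compounds than this note shows. Statements on the series, on what has been measured and on what is new or still open speak of the compounds shown alone.

Measured in an ADME assay on HCT-116 cells (Homo sapiens) for cytotoxicity, read by CellTiter-Glo, with a stated time of 72 h; on this read-out higher numbers stand for weaker inhibition and lower numbers for stronger inhibition:
compound 1 `Cc1c(C)c(S(=O)(=O)N2CCC(N3CCC(C)CC3)CC2)c(C)c2c1OC(C)(C)C2` gives > 10000 nM
compound 2 `COc1ccccc1-c1ccc(S(=O)(=O)N2CCC(N3CCC(C)CC3)CC2)cc1` gives > 5000 nM
compound 3 `CC1CCN(C2CCN(S(=O)(=O)c3cccc(-c4ccccc4F)c3)CC2)CC1` gives > 5000 nM

Compound 1 reports only a limit in this assay, not a number, namely (the limit of > 10000 nM in this assay, at which 1 of the 3 values shown sits). Compound 2 likewise reports only a limit, (the limit of > 5000 nM in this assay, at which 2 of the 3 values shown sit). Compound 3 also sits at a limit. So compound 2 stands where every value shown stands: at a limit, with no numbered result in the set to order it against.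

Compound 4 `CCc1ccc(S(=O)(=O)N2CCC(N3CCC(C)CC3)CC2)cc1` differs from compound 2 by ethyl in place of 2-methoxyphenyl on an aromatic carbon. Going by the values given here, no step between two measured compounds is available to size this change. The expected step that the limit leaves unreadable from compound 2 to compound 4 is none beyond the scatter, with a limit again the likeliest outcome. Compound 4 is therefore estimated at 20000 nM, in the range 5000 nM to 100000 nM.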

Compound 4, half-maximal inhibitory concentration: > 5000 nM
Compound 4 ended at the assay's limit; the forecaster's own chance of this, stated with the estimate: 85%; the middle value is on the limit's open side.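

Compound 2 and compound 4 both report only a limit, and no step can be read between them. The compounds shown leave open whether any substituent on the shared core gives a numbered cytotoxicity result.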